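The source may report more compounds than this note shows. Statements on the series, on what has been measured and on what is new or still open speak of the compounds shown alone.

Measured compounds in an ADME assay on BJ cells (Homo sapiens) for cytotoxicity, read by CellTiter-Glo and resazurin assay, with a stated time of 72 h; on this read-out higher numbers stand for an effect only at larger amounts of compound and lower numbers for an effect already at smaller amounts:
compound 1, `CCOC(=O)CCCCCOc1cccc(CN(C(=O)c2ccc(-c3cccc4ccccc34)cc2)C(C)C)c1`: only a limit, > 26000 nM
compound 2, `CCOC(=O)CCCCCOc1cccc(CN(C(=O)c2ccc(-c3ccc4[nH]ccc4c3)cc2)C(C)C)c1`: only a limit, > 26000 nM

In this assay compound 2 gives no number, only the limit > 26000 nM. The same holds for the other shown value: both sit at the limit of > 26000 nM in this assay, at which 2 of the 2 values shown sit. Going by the values given here, the one measured step, a step that the two limits leave unreadable from compound 1 to compound 2, is therefore unreadable; both ends of it are limits, so neither its size nor its direction can be taken from the data.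

Compound 3, `CCOC(=O)CCCCCOc1cccc(CN(C(=O)c2ccc(-c3cccc(CC(=O)O)c3)cc2)C(C)C)c1`, differs from compound 2 in one place: 3-(carboxymethyl)phenyl in place of 1H-indol-5-yl on an aromatic carbon.

Among the compounds with values here, no measured step bears on this change in a readable way. The only step known, from a naphthyl to an indolyl group, left both values at the limit, and that is all the shown numbers offer. Compound 3 is therefore expected to behave like compound 2 in this assay, with no step beyond the scatter, an expected step that the limit leaves unreadable from compound 2 to compound 3. The estimate for compound 3 in this assay is 30000 nM, with a range from 14000 nM to 70000 nM, and it is expected most likely to come back as a limit again.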

Compound 3, half-maximal effective concentration: > 26000 nM
Compound 3: a limit, no number; the forecaster's own chance of this, stated with the estimate: 85%; the middle value lies beyond the limit too.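

Going by these compounds alone, compound 3 also gives only a limit in this assay, so no step among compound 1, compound 2 and compound 3 can be read, in size or in direction: the limit of > 26000 nM in this assay, at which 3 of the 3 values shown sit. The compounds shown leave open whether any replacement of the group on this aromatic carbon changes the value in this assay at all.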